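Nitro-to-Methyl Swap Carried Over to a Second Core

The source may report more compounds than this note shows. Statements on the series, on what has been measured and on what is new or still open speak of the compounds shown alone.

Measured so far in a functional assay on CCRF-CEM cells (Homo sapiens) for inhibition; a higher number here means a weaker inhibitor, a lower number a stronger inhibitor:
Compound 1 `O=C1/C(=C/c2ccccc2[N+](=O)[O-])CCc2ccccc21` gives 7220 nM.
Compound 2 `Cc1ccccc1/C=C1\CCc2ccccc2C1=O` gives 43200 nM.
Compound 3 `O=C1/C(=C/c2ccccc2[N+](=O)[O-])Cc2ccccc21` gives 3530 nM.

Compound 2 differs from compound 1 by methyl in place of nitro on an aromatic carbon, and that change produced a 6.0-fold higher number from compound 1 to compound 2 (0.78 log units; beyond the scatter). Compound 3 has the lowest number of the three; how its core differs from the core of compound 1 is not broken down here. Compound 4 `Cc1ccccc1/C=C1\Cc2ccccc2C1=O` has not yet been measured. It differs from compound 3 by methyl in place of nitro on an aromatic carbon, at the same place as in the first pair, so it is the same change. Because the measured step was a 6.0-fold higher number from compound 1 to compound 2 (0.78 log units; beyond the scatter), the step expected in this assay is a 5.9-fold higher number from compound 3 to compound 4 (0.77 log units; beyond the scatter). Compound 4 is therefore estimated at 21000 nM, expected to lie between 8000 nM and 60000 nM.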

Compound 4, half-maximal inhibitory concentration: 56500 nM
For compound 4 the middle estimate is 2.7-fold (0.43 log units) below the measured one, within the range that was stated.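

In this assay, putting methyl in place of nitro again gave a weaker inhibitor, with a 16-fold higher number from compound 3 to compound 4 (1.20 log units; beyond the scatter) on the core of compound 3, so the direction of the change carried over from the core of compound 1. The size of the step did not carry over, since the two steps differ by more than the scatter: the same change on two cores in this assay, a 6.0-fold higher number (0.78 log units; beyond the scatter) from compound 1 to compound 2 and a 16-fold higher number (1.20 log units; beyond the scatter) from compound 3 to compound 4, 2.7-fold (0.43 log units) apart, beyond the scatter of two such steps. These two pairs show that the core can alter how much this change costs, but they do not explain the difference or show that the direction would hold on any other core.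

As far as these compounds go, only nitro and methyl appear at this place on the aromatic ring, so it remains open how an amine, a carboxylic acid or a nitrile would behave there. Only two cores are shown, which also leaves open how large the step would be on a third.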